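A few compounds are considered here, and "the series" means these few. Any claim that something is new, unique, unknown or untested is made for them only; others in the source may bear on it.

Measured compounds:
compound 1, `O=Cc1c(O)ccc2oc(-c3cccc4ccccc34)nc12`
compound 2, `COc1cc(OC)cc(-c2nc3c(C=O)c(O)ccc3o2)c1`
compound 3, `CC(=O)c1c(O)ccc2oc(-c3ccccc3)nc12`

All three share one core and differ in the groups attached to it. In a functional assay on HeLa cells (Homo sapiens) for cytotoxicity, read by MTT assay, with a stated time of 48 h (a higher number here means a weaker inhibitor, a lower number a stronger inhibitor), compound 1 gives 30100 nM. Compound 2 gives 25300 nM in this assay. These two values lie within the usual scatter of each other, so they show no difference between compound 1 and compound 2. For compound 3, this assay gives no number but only a limit, > 30000 nM, meaning that no inhibition strong enough to be measured was seen within the tested range. Compound 3 thus sits at the limit of > 30000 nM in this assay, at which 1 of the 3 values shown sits.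

The next compound, compound 4 `CC(=O)c1c(O)ccc2oc(-c3ccccc3C)nc12`, is not yet measured. It differs from compound 3 in one place: methyl in place of hydrogen on an aromatic carbon. For the measured compounds named here, a single small group of this kind, with no step measured for it among the compounds above, gives no ground to expect a change beyond the scatter. The step that the limit leaves unreadable from compound 3 to compound 4 is therefore expected to be small or absent. Compound 4 is expected to give 40000 nM, within a range from 15000 nM to 120000 nM.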

Compound 4, half-maximal inhibitory concentration: 19200 nM
Beside the measured number, compound 4's estimate is 2.1-fold (0.32 log units) above it, and the stated range covers the measured number.
By their numbers in this assay, from the lowest: compounds 4, 2 and 1 (each within the scatter of the next).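

Methyl in place of hydrogen on an aromatic carbon, ortho to a large group, gives an at least 1.5-fold lower number from compound 3 to compound 4 (0.19 log units; that floor lies within the scatter) in this assay, the first step seen at this position. For the compounds shown here, the result therefore offers a first reading of a single methyl here, but because the floor of the step lies within the scatter, it does not establish a real gain in cytotoxicity. The true size of the step remains unknown because compound 3 has only a limit: the limit of > 30000 nM in this assay, at which 1 of the 4 values shown sits.

From the compounds shown here alone, it remains open what an amine, a carboxylic acid or a longer chain would do at this same position. Going by these compounds, it is also open whether methyl would give a similar step on compounds carrying the aldehyde of compound 1 and compound 2 instead of the acetyl group of compound 3.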